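This account rests on a few compounds, and the source may have more. Where it says the series, first, only, none or still open, it means among the compounds named here.

Measured so far in a functional assay on QGY-7703 cells (Homo sapiens) for cytotoxicity, read by MTT assay, with a stated time of 24 h; on this read-out higher numbers stand for weaker inhibition and lower numbers for stronger inhibition:
compound 1 `O=C1/C(=C/c2cccnc2)CNC/C1=C\c1ccccc1F`: 8890 nM
compound 2 `O=C1/C(=C/c2cccnc2)CN(S(=O)(=O)c2ccccc2)C/C1=C\c1ccccc1F`: 4800 nM
compound 3 `O=C1/C(=C/c2cccnc2)CNC/C1=C\c1ccccc1C(F)(F)F`: 3800 nM

Compound 3 sits within the scatter of compound 2 and apart from compound 1, the gap to the latter being a 2.3-fold lower number from compound 1 to compound 3 (0.37 log units; beyond the scatter) in these notes.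

The next step leads to compound 4 `O=C1/C(=C/c2cccnc2)CN(S(=O)(=O)c2ccc(Cl)cc2)C/C1=C\c1ccccc1C(F)(F)F` and the change is (4-chlorophenyl)sulfonyl in place of hydrogen on an amine nitrogen in a ring with (4-chlorophenyl)sulfonyl in place of hydrogen on an amine nitrogen in a ring.

The closest measured step is a 1.9-fold lower number from compound 1 to compound 2 (0.27 log units; within the scatter) for phenylsulfonyl in place of hydrogen at the same nitrogen. It was measured with fluoro rather than trifluoromethyl on the other aromatic ring, and it lies within the scatter. Among the compounds with values here, no measured compound carries a sulfonyl group together with trifluoromethyl, so whether the two steps add up is untested. Within the data shown here, the chlorine of the entering group also has no measured counterpart.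

Resting on that single step from compound 1 to compound 2, a small move toward a lower number is expected in this assay and it may well stay within the scatter. The estimated move is a 1.9-fold lower number from compound 3 to compound 4 (0.28 log units; within the scatter) and no larger shift is expected. For compound 4 the estimate is 2000 nM with an expected range of 800 nM to 4800 nM on this read-out.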

Compound 4, half-maximal inhibitory concentration: 3440 nM
Compound 4: the middle estimate sits 1.7-fold (0.24 log units) below what was measured; low and high end bracket the measured number.
By their numbers in this assay, from the lowest: compounds 4, 3, 2 and 1 (each within the scatter of the next, the first and the last beyond it).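

In this assay, a 1.1-fold lower number from compound 3 to compound 4 (0.04 log units; within the scatter) places (4-chlorophenyl)sulfonyl on the amine nitrogen in the ring, and compound 4 is the only compound shown that pairs a sulfonyl group with trifluoromethyl. Together with a 1.9-fold lower number from compound 1 to compound 2 (0.27 log units; within the scatter), this gives two readings at this nitrogen, one with fluoro and one with trifluoromethyl on the aromatic ring, and both steps lie within the scatter, so neither pair separates the free amine nitrogen from its sulfonylated form. No available evidence bears on why substitution at this nitrogen leaves the number within the scatter in compound 4.

On these data alone, what the chlorine contributes by itself stays open, as compound 2 and compound 4 differ in two places and their values cannot isolate it. Also open, as far as these compounds go, is whether a different kind of group on this nitrogen, such as an acetyl group, a longer alkyl chain or a chain ending in a carboxylic acid, would give a step beyond the scatter in this assay.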